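Side-chain change from compound 3 to compound 4

The compounds below may be only part of what the source reports. "The series", "measured", "known", "first", "only" and "open" are said of these compounds alone.

Of the compounds shown here, three on a shared core have been measured. In a functional assay on MDA-MB-231 cells (Homo sapiens) for antiproliferative activity, read by MTT assay, with a stated time of 24 h (on this read-out lower numbers stand for stronger inhibition and higher numbers for weaker inhibition), compound 1 `CCCCc1oc2ccccc2c1C(=O)c1ccc(OCC(N)=O)cc1` gives > 50000 nM, which is a limit and not a number. Compound 3 `CCCCc1oc2ccccc2c1C(=O)c1ccc(OCC(=O)Nc2ccccc2)cc1` gives > 50000 nM, likewise a limit. Going by the values given here, compound 2 `CCCCc1oc2ccccc2c1C(=O)c1ccc(OCC(=O)N2CCN(C(=O)OC(C)(C)C)CC2)cc1` is the only one with a number, 36900 nM. Compound 3 therefore stands at the limit of > 50000 nM in this assay, at which 2 of the 3 values shown sit.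

Compound 4 `CCCCc1oc2ccccc2c1C(=O)c1ccc(OCCCC(=O)N2CCOCC2)cc1` carries 2-((morpholin-4-yl)carbonyl)ethyl in place of phenylcarbamoyl on a saturated chain carbon bound to an oxygen on an aromatic ring. Cut one bond further out, the same difference reads (phenylcarbamoyl)methyl to 3-((morpholin-4-yl)carbonyl)propyl.

Among the compounds with values here, the one measured step is a step that the two limits leave unreadable from compound 1 to compound 3, so it offers no size to carry over. The nearest guide is compound 2, which also has its amide nitrogen in a six-membered non-aromatic ring with 2 hetero atoms and gives 36900 nM. On that single value, compound 4 is expected to sit close to the top of the readable range. The step expected in this assay is an at least 1.3-fold lower number from compound 3 to compound 4 (0.11 log units; that floor lies within the scatter), small and toward stronger inhibition, with a real chance that only a limit is returned. For compound 4 the estimate is 38000 nM, with an expected range of 15000 nM to 50000 nM.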

Compound 4, half-maximal inhibitory concentration: 31600 nM
For compound 4 the middle estimate is 1.2-fold (0.08 log units) above the measured one; measured number inside the range.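

In this assay, going by these compounds alone, 2-((morpholin-4-yl)carbonyl)ethyl in place of phenylcarbamoyl on a saturated chain carbon bound to an oxygen on an aromatic ring gives the first step at this position with a readable floor, an at least 1.5-fold lower number from compound 3 to compound 4 (0.19 log units; that floor lies within the scatter), and the same group in place of carbamoyl reads an at least 1.5-fold lower number from compound 1 to compound 4 (0.19 log units; that floor lies within the scatter). Both steps are floors and not sizes, set by the limit shared by their starting compounds: the limit of > 50000 nM in this assay, at which 2 of the 4 values shown sit. The change from phenylcarbamoyl bundles several differences, since an aromatic ring of carbon only gives way to a six-membered non-aromatic ring with 2 hetero atoms, the hydrogen-bond donor count goes from 1 to 0, and the same difference, cut one bond further out, reads (phenylcarbamoyl)methyl to 3-((morpholin-4-yl)carbonyl)propyl, so the step cannot be assigned to any one of them.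

Going by these compounds, the true size of both steps stays open, as does the question of whether the ring or the chain length carries them. A (morpholin-4-yl)carbonylmethyl group, or a carboxylic acid at the end of the chain, would test this in this assay.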